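Bromo in place of hydrogen: compound 2 to compound 3

The source may hold more compounds than are shown below. What is called first, only, known or untested is meant among the compounds shown, and "the series" means these compounds.

Of the compounds shown here, two have been read so far in an ADME assay on NBT-T2 cells (Rattus norvegicus) for cytotoxicity, read by MTT assay; a higher number here means a weaker inhibitor, a lower number a stronger inhibitor. Compound 1 `Oc1c(Br)cc(Br)cc1Oc1c(Br)ccc(Br)c1O` gives > 15 ug/mL, which is a limit and not a number. Compound 2 `Oc1ccc(Br)cc1Oc1cc(Br)cc(Br)c1O` gives > 15 ug/mL, also a limit. Among the compounds with values here, compound 2 therefore has no exact place, and the only reading so far is the limit of > 15 ug/mL in this assay, at which 2 of the 2 values shown sit. No step can be read between these two compounds.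

Compound 3 `Oc1ccc(Br)cc1Oc1c(O)c(Br)cc(Br)c1Br` differs from compound 2 in one place: bromo in place of hydrogen on an aromatic carbon. The change is bromo in place of hydrogen on an aromatic carbon, ortho to a bromo group, para to a bromo group and meta to a hydroxy group.

Within the data shown here, no measured step shows what this change does in this assay. The expectation therefore leans on compound 2 at > 15 ug/mL, again a limit. The expected change is a step that the limit leaves unreadable from compound 2 to compound 3, with no step beyond the scatter anticipated in either direction. The estimate for compound 3 is 20 ug/mL, with an expected range of 10 ug/mL to 40 ug/mL, and another limit is the likeliest report.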

Compound 3, half-maximal inhibitory concentration: > 15 ug/mL
Compound 3: only a limit was reported; the forecaster's own chance of this, stated with the estimate: 70%; the middle value is on the limit's open side.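

No step can be read from compound 2 to compound 3, as each carries only a limit in this assay. The compounds shown leave open what bromo in place of hydrogen on this aromatic carbon does to the read-out, and where any of the three compounds would fall as an exact number: the limit of > 15 ug/mL in this assay, at which 3 of the 3 values shown sit.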